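This account rests on a few compounds, and the source may have more. Where it says the series, first, only, none or still open, it means among the compounds named here.

Two compounds share one core and differ only in the aromatic group attached to a saturated chain carbon bound to a carbonyl carbon and an oxygen on a saturated carbon. Compound 1 `COC(C(=O)OC(C)Cn1cnc2c1c(=O)n(C)c(=O)n2C)c1cccc2ccccc12` carries naphthalen-1-yl there; in a functional assay on CCRF-CEM cells (Homo sapiens) for antiproliferative activity, read by MTT assay, with a stated time of 72 h, tested at 25 uM (on this read-out higher numbers stand for a weaker effect at the one concentration tested and lower numbers for a stronger effect), compound 1 gives 96.6%. Compound 2 `COC(C(=O)OC(C)Cn1cnc2c1c(=O)n(C)c(=O)n2C)c1ccc2ccccc2c1` carries naphthalen-2-yl instead, and in this assay compound 2 gives 84.7%. Among the compounds with values here, that single change gives a number 11.9 percentage points lower from compound 1 to compound 2 (beyond the scatter), so compound 2 stands lowest of the two numbers, with compound 1 as its only neighbour.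

Compound 3 `COC(C(=O)OC(C)Cn1cnc2c1c(=O)n(C)c(=O)n2C)c1ccc(C(C)(C)C)cc1` is not yet measured. It differs from compound 2 by 4-(tert-butyl)phenyl in place of naphthalen-2-yl on a saturated chain carbon bound to a carbonyl carbon and an oxygen on a saturated carbon. Within the data shown here, no measured step concerns this kind of exchange; the only step known moves the point of attachment within a naphthalene and is modest. The step from compound 2 to compound 3 in this assay is therefore expected to be small, a number 3.3 percentage points higher from compound 2 to compound 3 (within the scatter), with a slight lean upward given how high compound 1 sits. Compound 3 is thus expected to give 88% in this assay, estimated within 70% to 100%.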

Compound 3, a percentage reported as activity, at one concentration (the size of the read-out at that concentration, not a potency): 75.8%
The estimate for compound 3 lay 12.2 percentage points above the measured number; the range from low to high includes it.
By their numbers in this assay, from the lowest: compounds 3 and 2 (each within the scatter of the next); then compound 1.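

Replacing the two fused rings of naphthalen-2-yl with the single ring of 4-(tert-butyl)phenyl, with the heavy-atom count unchanged at 10 carbons, gives a number 8.9 percentage points lower from compound 2 to compound 3 (within the scatter) in this assay. A second fused aromatic ring is therefore not needed at this position to keep the read-out at the level of the naphthalen-2-yl compound, while exchanging naphthalen-1-yl for the same group gives a number 20.8 percentage points lower from compound 1 to compound 3 (beyond the scatter), the widest gap among the compounds shown. No measurement here explains why these groups differ in this way.

The compounds shown leave open how a plain phenyl, or a phenyl carrying an amine or a carboxylic acid, would read at this position. They also leave open whether a longer chain in place of the tert-butyl would change the number.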